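The source may hold more compounds than are shown below. What is called first, only, known or untested is meant among the compounds shown, and "the series" means these compounds.

Series notes. Compound 1 `COc1cc2c(Oc3ccc(NC(=O)Nc4ccccc4)cc3)ccnc2cc1OCCCCCCC(=O)NO` gives 1040 nM in a functional assay on MCF7 cells (Homo sapiens) for antiproliferative activity, read by MTT assay; a higher number here means a weaker inhibitor, a lower number a stronger inhibitor. Compound 2 `COc1cc2c(Oc3ccc(NC(=O)Nc4ccccc4F)cc3)ccnc2cc1OCCCCCCC(=O)NO` carries fluoro in place of hydrogen on an aromatic carbon and gives 660 nM in this assay; the step of a 1.6-fold lower number from compound 1 to compound 2 (0.20 log units; within the scatter) is small. Compound 3 `COc1cc2c(Oc3ccc(NC(=O)NNC(=O)c4ccccc4)cc3)ccnc2cc1OCCCCCCC(=O)NO` has a different core, described by benzamido in place of phenyl on an amide-type nitrogen; in this assay compound 3 gives 2450 nM, the step being a 2.4-fold higher number from compound 1 to compound 3 (0.37 log units; beyond the scatter), and against compound 2 the step is a 3.7-fold higher number from compound 2 to compound 3 (0.57 log units; beyond the scatter).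

Compound 4 `COc1cc2c(Oc3ccc(NC(=O)NNC(=O)c4ccccc4F)cc3)ccnc2cc1OCCCCCCC(=O)NO` is not yet measured. It differs from compound 3 by fluoro in place of hydrogen on an aromatic carbon. This is the same change as from compound 1 to compound 2, and the place is described in the same words for both; one bond further out the surroundings read anilino against benzamido, so the core around the change differs as told by benzamido in place of phenyl on an amide-type nitrogen.

Among the measured compounds shown here, the only precedent for this change is the small step from compound 1 to compound 2, which rests on a single pair and is within the scatter. A step of the same size is expected here, so for compound 4 the estimated step is a 1.4-fold lower number from compound 3 to compound 4 (0.16 log units; within the scatter). In this assay compound 4 is expected to give about 1700 nM, between 800 nM and 3600 nM.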

Compound 4, half-maximal inhibitory concentration: 3600 nM
Compound 4: the middle estimate sits 2.1-fold (0.33 log units) below what was measured; the measured number falls inside the stated range.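

In this assay fluoro in place of hydrogen on an aromatic carbon gives a small step on the core of compound 1 and on the core of compound 3, here a 1.5-fold higher number from compound 3 to compound 4 (0.17 log units; within the scatter) and the two steps do not separate: the same change on two cores in this assay, a 1.6-fold lower number (0.20 log units; within the scatter) from compound 1 to compound 2 and a 1.5-fold higher number (0.17 log units; within the scatter) from compound 3 to compound 4, 2.3-fold (0.36 log units) apart, within the scatter of two such steps. The opposite printed directions therefore carry no weight, and the change shows no detectable dependence on the core, but two pairs, each within the scatter, cannot show that it has a real effect or a fixed sign on either core. The larger differences lie in the replacement on the amide-type nitrogen, with a 5.5-fold higher number from compound 2 to compound 4 (0.74 log units; beyond the scatter) and a 3.5-fold higher number from compound 1 to compound 4 (0.54 log units; beyond the scatter) both beyond the scatter, and these steps do not isolate the fluoro.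

The compounds shown leave open whether chloro or methyl in place of the fluoro would also give only a small step on these two cores. They also leave open how either core would respond with a shorter alkyl chain carrying the terminal hydroxamic acid.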